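The compounds below may be only part of what the source reports. "The series", "measured", "known", "first", "only" and "open" are said of these compounds alone.

In a functional assay on A549 cells (Homo sapiens) for antiproliferative activity, read by MTT assay, with a stated time of 48 h (on this read-out higher numbers stand for weaker inhibition and lower numbers for stronger inhibition), the three measured compounds gave the following numbers:

compound 1 `COc1ccc(N/C=C\C(=O)c2cn(-c3ccccc3)nc2-c2ccc(Cl)cc2)cc1`: 6460 nM
compound 2 `COc1cc(-c2nn(-c3ccccc3)cc2C(=O)/C=C\Nc2ccc(Cl)cc2)cc(OC)c1OC`: 8670 nM
compound 3 `COc1cc(-c2nn(-c3ccccc3)cc2C(=O)/C=C\Nc2ccc(O)cc2)cc(OC)c1OC`: 3160 nM

Compound 3 thus holds the lowest number of the three; compound 1 stands nearest to it and compound 2 furthest away. Among the measured compounds shown here, the one measured step that touches compound 3 is a 2.7-fold lower number from compound 2 to compound 3 (0.44 log units; beyond the scatter). Compound 4 `COc1ccc(N/C=C\C(=O)c2cn(-c3ccccc3)nc2-c2cc(OC)c(OC)c(OC)c2)cc1` differs from compound 3 by methyl in place of hydrogen on an oxygen on an aromatic ring. For the measured compounds named here, no measured pair shows this particular exchange, so the step from compound 2 to compound 3 bears on it only by showing that the substituent on this aromatic ring can move the number by a modest amount. Compound 1 carries the same methoxy group on this ring yet differs elsewhere as well, and its value sits above that of compound 3; it can hint at the direction but cannot fix the size. On this basis compound 4 is expected to show a small to modest rise in this assay, a 1.6-fold higher number from compound 3 to compound 4 (0.20 log units; within the scatter). The estimate for compound 4 is therefore 5000 nM, with a range from 2000 nM to 12000 nM.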

Compound 4, half-maximal inhibitory concentration: 4780 nM
Beside the measured number, compound 4's estimate is 1.0-fold (0.02 log units) above it; the measured number falls inside the stated range.
By their numbers in this assay, from the lowest: compounds 3, 4, 1 and 2 (each within the scatter of the next, the first and the last beyond it).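

In this assay, methyl in place of hydrogen on this oxygen gives a 1.5-fold higher number from compound 3 to compound 4 (0.18 log units; within the scatter), so hydroxy and methoxy at this place cannot be told apart, and the free hydrogen on the oxygen is not shown to matter here. Methoxy in place of chloro gives a 1.8-fold lower number from compound 2 to compound 4 (0.26 log units; within the scatter), whereas hydroxy in place of chloro gives a 2.7-fold lower number from compound 2 to compound 3 (0.44 log units; beyond the scatter), so only the hydroxy compound stands clear of the chloro compound. With methoxy held in this place, 3,4,5-trimethoxyphenyl in place of 4-chlorophenyl gives a 1.4-fold lower number from compound 1 to compound 4 (0.13 log units; within the scatter), so that exchange cannot be read as a real change either.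

No measurement is at hand that explains these numbers. On these data alone, whether an amine or a carboxylic acid on this aromatic ring would move the number further remains open.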